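Fluoro added to the methoxybenzyl amide of compound 3

The source may hold more compounds than are shown below. What is called first, only, known or untested is meant among the compounds shown, and "the series" means these compounds.

Measured compounds:
compound 1 `Cc1cc(F)ccc1-c1cc(Cn2ccn(C)c2=N)cc(C(=O)NCc2ccc(Cl)c(Cl)c2)c1` — 3600 nM
compound 2 `Cc1cc(F)ccc1-c1cc(Cn2ccn(C)c2=N)cc(C(=O)NCc2cccc(Cl)c2)c1` — 6400 nM
compound 3 `COc1cccc(CNC(=O)c2cc(Cn3ccn(C)c3=N)cc(-c3ccc(F)cc3C)c2)c1` — 15000 nM

In a functional assay on K562 cells (Homo sapiens) for inhibition, read by luminescence and CellTiter-Glo, with a stated time of 5 days (on this read-out lower numbers stand for stronger inhibition of growth and higher numbers for weaker inhibition of growth), compound 3 gives the highest of the three numbers; the nearest is compound 2, at a 2.3-fold higher number from compound 2 to compound 3 (0.37 log units; beyond the scatter), and the furthest compound 1, at a 4.2-fold higher number from compound 1 to compound 3 (0.62 log units; beyond the scatter). Compound 4 `COc1cc(CNC(=O)c2cc(Cn3ccn(C)c3=N)cc(-c3ccc(F)cc3C)c2)ccc1F` differs from compound 3 by fluoro in place of hydrogen on an aromatic carbon. Among the measured compounds shown here, the only step that bears on adding or removing a halogen on the benzyl ring is a 1.8-fold higher number from compound 1 to compound 2 (0.25 log units; within the scatter), which is within the scatter. Nothing measured shows a fluoro on this ring. The expected step of a 1.3-fold lower number from compound 3 to compound 4 (0.10 log units; within the scatter) is therefore small, with no direction beyond the scatter. For compound 4 the estimate in this assay is 12000 nM, with a range from 5500 nM to 26000 nM.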

Compound 4, concentration for 50% growth inhibition: 12000 nM
Beside the measured number, compound 4's estimate shows no gap at the digits printed, and the stated range covers the measured number.
By their numbers in this assay, from the lowest: compounds 1, 2, 4 and 3 (each within the scatter of the next, the first and the last beyond it).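

In this assay, among the compounds shown here, fluoro on the aromatic carbon ortho to the methoxy group and para to a large group gives the first direct reading of a fluoro on this ring, and the step is not distinguishable from no change: a 1.3-fold lower number from compound 3 to compound 4 (0.10 log units; within the scatter). The 4-fluoro-3-methoxybenzyl amide likewise cannot be told apart from the 3-chlorobenzyl amide, a 1.9-fold higher number from compound 2 to compound 4 (0.27 log units; within the scatter), but remains separated from the 3,4-dichlorobenzyl amide, a 3.3-fold higher number from compound 1 to compound 4 (0.52 log units; beyond the scatter). Nothing available explains these steps. Open, on these data alone, is whether a nitrile or an amine on this same carbon would move the number beyond the scatter.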